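This account rests on a few compounds, and the source may have more. Where it says the series, first, only, none or still open, it means among the compounds named here.

Measured so far:
Compound 1, `CC(C)Cc1ccc(C(C)C2=NNC(S)N2N)cc1`, gives 50% in a functional assay on the whole organism (strain Wistar albino) for inhibition, with Rattus norvegicus as the target, read by paw edema, with stated times of 30 min and 2.5 h, at a dose of 20 mg/kg by the oral route; a lower number here means less inhibition, a higher number more inhibition at the dose given (going by the name of the read-out).
Compound 2, `CC(C)Cc1ccc(C(C)c2nnc(S)n2/N=C/c2ccc(Cl)cc2)cc1`, gives 62% in this assay.

Among the measured compounds shown here, compound 2 stands highest of the two numbers known in this assay; its nearest neighbour is compound 1, whose value is lower by a gap beyond the usual scatter of this kind of measurement. For the measured compounds named here, no step between two measured compounds that differ in a single place has been recorded, so there is no measured precedent for the change now in question.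

Compound 3, `CC(C)Cc1ccc(C(C)c2nnc(S)n2/N=C/c2ccc(Br)cc2)cc1`, has not yet been measured. It differs from compound 2 in one place: bromo in place of chloro on an aromatic carbon. Going by the values given here, exchanging one halogen for another is a modest alteration, and nothing in the two known numbers points either way. In this assay the expected step is no change at the digits printed from compound 2 to compound 3 (within the scatter), which is no change beyond the scatter. Compound 3 is expected to give 62%, within a range from 50% to 74%.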

Compound 3, a percentage reported as inhibition, in the whole organism at one dose (the size of the read-out at that dose, not a potency): 70%
The estimate for compound 3 lay 8 percentage points below the measured number; the measured number falls inside the stated range.
By their numbers in this assay, from the lowest: compound 1; then compounds 2 and 3 (each within the scatter of the next).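

In this assay, putting bromo in place of chloro on this aromatic carbon gives a number 8 percentage points higher from compound 2 to compound 3 (within the scatter), so at this dose the two halogens cannot be told apart at this position. Among the compounds shown here, this is the only step here between compounds that differ in one place, and it shows that this position, para to a large group, can carry either chloro or bromo with no change beyond the scatter. No measurement at hand bears on why the two compounds read alike.

On these data alone, it remains open whether a fluoro, methoxy, nitro or amino group at the same place would keep the read-out, and whether a plain phenyl without any halogen would do the same. Since each number reflects one dose, the comparison also says nothing about potency.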